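The source may report more compounds than this note shows. Statements on the series, on what has been measured and on what is new or still open speak of the compounds shown alone.

Of the compounds shown here, three built on one shared core have been tested in a functional assay on UACC-257 cells (Homo sapiens) for inhibition, read by sulforhodamine B assay, with a stated time of 48 h; on this read-out lower numbers stand for higher toxicity in this test and higher numbers for lower toxicity in this test. Compound 1 `C=C1CC[C@@H]2[C@](C)(COC(C)=O)[C@H](OC(C)=O)CC[C@@]2(C)[C@H]1CC(Nc1ccc(S(=O)(=O)Nc2nccc(C)n2)cc1)C1=CCOC1=O` gives 42800 nM, compound 2 `C=C1CC[C@@H]2[C@](C)(COC(C)=O)[C@H](OC(C)=O)CC[C@@]2(C)[C@H]1CC(Nc1ccc(S(=O)(=O)Nc2nccs2)cc1)C1=CCOC1=O` gives 17200 nM, and compound 3 `C=C1CC[C@@H]2[C@](C)(COC(C)=O)[C@H](OC(C)=O)CC[C@@]2(C)[C@H]1CC(Nc1ccc(S(=O)(=O)Nc2ncccn2)cc1)C1=CCOC1=O` gives 21900 nM. Compound 2 stands at the lowest of these three numbers, nearest to compound 3 and furthest from compound 1. The as yet unmeasured compound 4 `C=C1CC[C@@H]2[C@](C)(COC(C)=O)[C@H](OC(C)=O)CC[C@@]2(C)[C@H]1CC(Nc1ccc(S(=O)(=O)Nc2cc(C)on2)cc1)C1=CCOC1=O` differs from compound 2 in a single place: 5-methyl-1,2-oxazol-3-yl in place of 1,3-thiazol-2-yl on a sulfonamide nitrogen. Two measured steps alter the same sulfonamide nitrogen and so bear on this change. The step of a 2.5-fold lower number from compound 1 to compound 2 (0.40 log units; beyond the scatter) lay beyond the scatter, whereas the step of a 1.3-fold higher number from compound 2 to compound 3 (0.10 log units; within the scatter) stayed within it. Among the compounds with values here, for the exchange of one ring group for another in compound 4 no measured pair exists, so the expected step of a 1.3-fold higher number from compound 2 to compound 4 (0.11 log units; within the scatter) is a small one, a modest rise at most, which may not exceed the scatter. Compound 4 is therefore estimated to give 22000 nM in this assay, with a range from 9000 nM to 50000 nM.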

Compound 4, concentration lethal to 50% of the cells: 18700 nM
The estimate for compound 4 lay 1.2-fold (0.07 log units) above the measured number; the measured number falls inside the stated range.
By their numbers in this assay, from the lowest: compounds 2, 4, 3 and 1 (each within the scatter of the next, the first and the last beyond it).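

In this assay, 5-methyl-1,2-oxazol-3-yl on the sulfonamide nitrogen cannot be told apart from 1,3-thiazol-2-yl (a 1.1-fold higher number from compound 2 to compound 4 (0.04 log units; within the scatter)) or from pyrimidin-2-yl (a 1.2-fold lower number from compound 3 to compound 4 (0.07 log units; within the scatter)), so a second five-membered aromatic ring, this one carrying a methyl, reads the same as the first. Only the exchange for 4-methylpyrimidin-2-yl passes the scatter (a 2.3-fold lower number from compound 1 to compound 4 (0.36 log units; beyond the scatter)), as it did for compound 2, although compound 3 stays within the scatter of compound 1. Nothing available explains these small differences. The compounds shown leave open whether a phenyl ring or an acetyl group on the sulfonamide nitrogen would move the number beyond the scatter of this set, and whether the methyl of 5-methyl-1,2-oxazol-3-yl contributes anything on its own.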